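This account rests on a few compounds, and the source may have more. Where it says the series, first, only, none or still open, it means among the compounds named here.

In an ADME assay on cells (Homo sapiens) for cytotoxicity, read by resazurin assay, with a stated time of 5 days (on this read-out lower numbers stand for higher toxicity in this test and higher numbers for lower toxicity in this test), compound 3 `O=S(=O)(Cc1nc(-c2ccc(Cl)nc2)c2sccc2n1)c1cccc(Cl)c1` gives 70000 nM. Compound 1 `COc1ccc(Nc2nc(CS(=O)(=O)c3cccc(Cl)c3)nc3ccsc23)cc1` gives 60000 nM, and the two numbers cannot be told apart: the measured move is a 1.2-fold higher number from compound 1 to compound 3 (0.07 log units; within the scatter), with 6-chloropyridin-3-yl in place of (4-methoxyphenyl)amino. Compound 2 `O=S(=O)(Cc1nc(-c2ccncc2)c2sccc2n1)c1cccc(Cl)c1`, which carries pyridin-4-yl, reads > 50000 nM, and this value is a limit of the assay and not a number. The two steps that touch it therefore give no size: there is a step that the limit leaves unreadable from compound 1 to compound 2, and there is a step that the limit leaves unreadable from compound 2 to compound 3.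

The next change leads to compound 4 `O=S(=O)(Cc1nc(-c2ccnc(Cl)c2)c2sccc2n1)c1cccc(Cl)c1`. It is 2-chloropyridin-4-yl in place of 6-chloropyridin-3-yl on an aromatic carbon, the same atoms joined differently, with 2-chloropyridin-4-yl in place of 6-chloropyridin-3-yl on an aromatic carbon of the shared core. For the measured compounds named here, no measured step covers this exchange directly, so the only readable guide is the step between compound 1 and compound 3. No step beyond the scatter is expected in this assay, because a 1.2-fold higher number from compound 1 to compound 3 (0.07 log units; within the scatter) was all that replacing (4-methoxyphenyl)amino with 6-chloropyridin-3-yl produced. The step expected is a 1.2-fold lower number from compound 3 to compound 4 (0.07 log units; within the scatter). For compound 4 the estimated value is 60000 nM, with an expected range from 30000 nM to 100000 nM.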

Compound 4, half-maximal cytotoxic concentration: 63000 nM
Beside the measured number, compound 4's estimate is 1.1-fold (0.02 log units) below it; low and high end bracket the measured number.
By their numbers in this assay, from the lowest: compounds 1, 4 and 3 (each within the scatter of the next).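

In this assay, the exchange of 6-chloropyridin-3-yl for 2-chloropyridin-4-yl, the same atoms joined differently, gives a difference that stays within the scatter: a 1.1-fold lower number from compound 3 to compound 4 (0.05 log units; within the scatter). For the compounds shown here, this is the first pair to show that, for these two groups at this position on the shared core, the way the atoms are joined does not separate the values. The result also extends what compound 1 and compound 3 showed, as 2-chloropyridin-4-yl in place of (4-methoxyphenyl)amino likewise leaves the values indistinguishable: a 1.1-fold higher number from compound 1 to compound 4 (0.02 log units; within the scatter).

Compound 2, which carries pyridin-4-yl, gives > 50000 nM, a limit of the assay and not a number, and none of the steps touching it can be read, including the one that adds chloro: the limit of > 50000 nM in this assay, at which 1 of the 4 values shown sits.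

As far as these compounds go, what chloro itself contributes on the pyridine ring therefore remains open. Also open, from the compounds shown here alone, is whether a different kind of group on this aromatic carbon, such as a carboxylic acid, a morpholine or a longer alkyl chain, would give a value beyond the scatter of those seen here.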